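Replacing a chlorophenyl amide by a phenylethenyl amide

This account rests on a few compounds, and the source may have more. Where it says the series, first, only, none or still open, it means among the compounds named here.

Of the compounds shown here, three built on one shared core have been tested in a functional assay on MDA-MB-231 cells (Homo sapiens) for antiproliferative activity, read by MTT assay, with a stated time of 48 h; on this read-out lower numbers stand for stronger inhibition and higher numbers for weaker inhibition. Compound 1 `O=C(/C=C/c1ccc([N+](=O)[O-])cc1)Nc1cc(Sc2ncn[nH]2)c(O)c2ccccc12` carries an amide with a 2-phenylethenyl group that bears a nitro substituent. In this assay compound 1 reaches only a limit, > 100000 nM. Compound 2 `O=C(Nc1cc(Sc2ncn[nH]2)c(O)c2ccccc12)c1cccc([N+](=O)[O-])c1` carries an aromatic amide bearing a nitro group, and in this assay compound 2 gives 48000 nM. Compound 3 `O=C(Nc1cc(Sc2ncn[nH]2)c(O)c2ccccc12)c1cccc(Cl)c1` carries a 3-chlorophenyl amide instead. In this assay compound 3 reaches only a limit, > 100000 nM, the same kind of limit noted as the limit of > 100000 nM in this assay, at which 2 of the 3 values shown sit. Among the measured compounds shown here, the single measured step between neighbours, an at least 2.0-fold higher number from compound 2 to compound 3 (0.31 log units; beyond the scatter), shows compound 3 weaker than compound 2.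

Compound 4 `O=C(/C=C/c1ccccc1)Nc1cc(Sc2ncn[nH]2)c(O)c2ccccc12` differs from compound 3 in one place: 2-phenylethenyl in place of 3-chlorophenyl on a carbonyl carbon. For the measured compounds named here, no measured step covers this change; the step of an at least 2.0-fold higher number from compound 2 to compound 3 (0.31 log units; beyond the scatter) only exchanges one substituent on an aromatic ring, whereas the change to compound 4 replaces the whole 3-chlorophenyl group by a 2-phenylethenyl group. What the numbers do show is that compound 1, which also carries a 2-phenylethenyl group, sits at the limit. Compound 4 is therefore expected to stay at or near that limit, with the step of a number no higher from compound 3 to compound 4 (the limit leaves the size open) estimated as none beyond the scatter. Compound 4 is estimated at 100000 nM, within a range from 40000 nM to 300000 nM.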

Compound 4, half-maximal inhibitory concentration: > 100000 nM
Compound 4: only a limit was reported; the forecaster's own chance of this, stated with the estimate: 65%; the middle value sits exactly at the limit.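

In this assay compound 4 gives > 100000 nM, which is a limit of the assay and not a number, so taking the nitro group off the 2-phenylethenyl group of compound 1 brings no measurable value into view. Placing 2-phenylethenyl instead of 3-nitrophenyl on the carbonyl carbon gives an at least 2.0-fold higher number from compound 2 to compound 4 (0.31 log units; beyond the scatter), so a second group at this position, after 3-chlorophenyl, ends up weaker than the group in compound 2. The steps from compound 3 to compound 4 and from compound 1 to compound 4 cannot be read, and the series now gathers at a single ceiling: the limit of > 100000 nM in this assay, at which 3 of the 4 values shown sit.

Among the compounds shown here, compound 2 remains the only compound here with a true number, so the limits hide any differences among the other three compounds, and how much the value of compound 2 depends on its nitro group remains unclear. Going by these compounds, whether an amine, a carboxylic acid or a longer chain on this carbonyl carbon would bring a value inside the range of this assay, or even surpass compound 2, remains open.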